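Compound 3 to compound 4: a methyl group moves

A few compounds are considered here, and "the series" means these few. Any claim that something is new, unique, unknown or untested is made for them only; others in the source may bear on it.

Compound 1 `COc1ccc(/C=C(\C#N)C(=O)Nc2ccccc2OC)cc1` gives > 200000 nM (a limit)
Compound 2 `COc1ccccc1NC(=O)/C(C#N)=C/c1ccccc1C` gives > 200000 nM (a limit)
Compound 3 `COc1ccccc1NC(=O)/C(C#N)=C/c1cccc(C)c1` gives > 200000 nM (a limit)

In an ADME assay on HBZY-1 cells (Rattus norvegicus) for cytotoxicity, read by MTT assay, with a stated time of 2 h (a higher number here means a weaker inhibitor, a lower number a stronger inhibitor), compound 3 gives > 200000 nM as a limit of the assay and not as a number. The whole set so far comes down to the limit of > 200000 nM in this assay, at which 3 of the 3 values shown sit, and no actual number has been seen yet.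

Compound 4 `COc1ccccc1NC(=O)/C(C#N)=C/c1ccc(C)cc1` carries 4-methylphenyl in place of 3-methylphenyl on a double-bonded chain carbon bound to a double-bonded chain carbon. The two have the same atoms, joined differently (4-methylphenyl in place of 3-methylphenyl on a double-bonded chain carbon bound to a double-bonded chain carbon).

The closest measured change is a step that the two limits leave unreadable from compound 2 to compound 3 and it swaps the same kind of group. From the compounds shown here alone, both ends of that step are limits, so its size stays unknown and it offers no sign of any shift. No step beyond the usual scatter is therefore expected in this assay for this change.

The expected result is a number no higher from compound 3 to compound 4 (the limit leaves the size open) and this remains only an estimate. Compound 4 is estimated at 200000 nM with an expected range of 100000 nM to 400000 nM and will most likely be reported only as a limit.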

Compound 4, half-maximal inhibitory concentration: > 200000 nM
Compound 4: only a limit was reported; the forecaster's own chance of this, stated with the estimate: 85%; the middle value lies on the limit itself.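

In this assay compound 4 gives > 200000 nM, a limit and not a number, so its steps from compound 1, compound 2 and compound 3 cannot be read. Whether moving the methyl group changes cytotoxicity at all stays open, since every value sits at one limit: the limit of > 200000 nM in this assay, at which 4 of the 4 values shown sit.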